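A few compounds are considered here, and "the series" means these few. Any claim that something is new, unique, unknown or untested is made for them only; others in the source may bear on it.

Three compounds share one core and differ only in the substituent on the benzyl part. In an assay on Sf21 cells for inhibition of high affinity nerve growth factor receptor (Homo sapiens), read by HTRF, with a stated time of 30 min, in the presence of a further agent that is not named here (a higher number here means a weaker inhibitor, a lower number a stronger inhibitor), compound 1 `COc1cccc(CN2Cc3c(NC(=O)c4ccccc4)n[nH]c3C2(C)C)c1` gives 1120 nM; compound 2 `CC1(C)c2[nH]nc(NC(=O)c3ccccc3)c2CN1Cc1cccc(C#N)c1` gives 980 nM; compound 3 `CC1(C)c2[nH]nc(NC(=O)c3ccccc3)c2CN1Cc1cccc(Br)c1` gives 940 nM. Compound 3 has the lowest of the three numbers, but the steps of a 1.2-fold lower number from compound 1 to compound 3 (0.08 log units; within the scatter) and a 1.0-fold lower number from compound 2 to compound 3 (0.02 log units; within the scatter) both lie within the scatter, so the three cannot be told apart. Compound 4 `CC1(C)c2[nH]nc(NC(=O)c3ccccc3)c2CN1Cc1ccc(F)cc1` carries 4-fluorophenyl in place of 3-bromophenyl on a saturated chain carbon bound to an amine nitrogen in a ring. For the measured compounds named here, no measured step makes this exact swap, yet every change tried at this ring, including a 1.1-fold lower number from compound 1 to compound 2 (0.06 log units; within the scatter), left the numbers level, so no step beyond the scatter is expected in this assay. Compound 4 is therefore estimated at 1000 nM, between 450 nM and 2300 nM. The expected step is a 1.1-fold higher number from compound 3 to compound 4 (0.03 log units; within the scatter).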

Compound 4, half-maximal inhibitory concentration: 1180 nM
For compound 4 the middle estimate is 1.2-fold (0.07 log units) below the measured one; low and high end bracket the measured number.
By their numbers in this assay, from the lowest: compounds 3, 2, 1 and 4 (each within the scatter of the next).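

In this assay the swap to 4-fluorophenyl leaves the numbers level, with every step inside the scatter: (a 1.3-fold higher number from compound 3 to compound 4 (0.10 log units; within the scatter)), (a 1.2-fold higher number from compound 2 to compound 4 (0.08 log units; within the scatter)) and (a 1.1-fold higher number from compound 1 to compound 4 (0.02 log units; within the scatter)). The earlier level picture came only from 3-bromophenyl, 3-cyanophenyl and 3-methoxyphenyl, and it now extends to a ring whose substituent and numbering both differ. No measurement here offers an explanation for this flat result. Still open, from the compounds shown here alone, is whether a ring carrying an amine or a carboxylic acid, or a longer chain at this carbon, would shift the number beyond the scatter.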